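Trimming one methyl from an ester chain

A few compounds are considered here, and "the series" means these few. Any claim that something is new, unique, unknown or untested is made for them only; others in the source may bear on it.

Measured so far:
Compound 1 `CCCOC(=O)C1=C(C)N(C)C(=O)NC1c1ccco1` gives 8% in an assay on membranes from HeLa cells for displacement of a labelled ligand from adenosine receptor A3 (Homo sapiens), read by scintillation counting, with a stated time of 180 min, tested at 1 uM; a lower number here means less inhibition, a higher number more inhibition at the concentration tested (going by the name of the read-out).
Compound 2 `CC1=C(C(=O)OCC(C)C)C(c2ccco2)NC(=O)N1C` gives 23% in this assay.
Compound 3 `CCC(CC)OC(=O)C1=C(C)NC(=O)NC1c1cccs1` gives 1% in this assay.

Compounds 1 and 2 share one core; compound 3 carries another, and the difference between the two cores is not broken down here. Going from compound 2 to compound 1, the change is hydrogen in place of methyl on a saturated chain carbon bound to two saturated chain carbons, and a number 15 percentage points lower from compound 2 to compound 1 (beyond the scatter).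

Compound 4 `CCC(C)OC(=O)C1=C(C)NC(=O)NC1c1cccs1` is the same kind of change made on compound 3: hydrogen in place of methyl on a saturated chain carbon, two bonds along the chain from an oxygen next to a carbonyl group. The two places are not the same word for word: in compound 2 the carbon bearing the methyl is bound to two saturated chain carbons, while in compound 3 it sits two bonds along the chain from an oxygen next to a carbonyl group.

Among the measured compounds shown here, the only measured step of this kind went down, and compound 3 already stands low, so only a small movement is expected. Compound 4 is expected to give 2% in this assay, within -8% to 14%. The expected step is a number 1 percentage points higher from compound 3 to compound 4 (within the scatter).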

Compound 4, a percentage reported as inhibition, at one concentration (the size of the read-out at that concentration, not a potency): 7%
For compound 4 the middle estimate is 5 percentage points below the measured one, and the stated range covers the measured number.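

On the core of compound 3, the change from pentan-3-yl to sec-butyl gives a number 6 percentage points higher from compound 3 to compound 4 (within the scatter), so no real movement can be claimed on that core in this assay. The fall seen on the core of compound 1 therefore does not carry over to the core of compound 3, and the two results differ by more than scatter alone would allow: the same change on two cores in this assay, a number 15 percentage points lower (beyond the scatter) from compound 2 to compound 1 and a number 6 percentage points higher (within the scatter) from compound 3 to compound 4, 21 percentage points apart, beyond the scatter of two such steps

This does not show which part of the two cores matters, and the comparison is limited in other ways: it rests on a single pair on each core, the trimmed chains are not the same, and each number comes from one tested concentration and is not a potency.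

The compounds shown leave open whether the sec-butyl chain of compound 4 would behave the same way on the core of compound 1. They also leave open how a longer chain, or an amide in place of the ester, would fare on either core.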